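Replacing a methyl ester hydrogen with an oxan-2-yl group

The source may hold more compounds than are shown below. What is called first, only, known or untested is meant among the compounds shown, and "the series" means these compounds.

Of the compounds shown here, two sharing one core have been measured in a functional assay on aorta with Voltage-dependent L-type calcium channel subunit alpha-1C (Oryctolagus cuniculus) as the target; a lower number here means a stronger inhibitor, a higher number a weaker inhibitor. Compound 1, `CC1=NC(C)=C(C(=O)OCN2C(=O)c3ccccc3S2(=O)=O)C(c2cccc([N+](=O)[O-])c2)/C1=C(\O)OC(C)(C)C`, gives 7.8 nM. Compound 2, `CO/C(O)=C1\C(C)=NC(C)=C(C(=O)OCN2C(=O)c3ccccc3S2(=O)=O)C1c1ccccc1[N+](=O)[O-]`, gives 30.9 nM, the higher of the two numbers, so compound 2 is the weaker inhibitor of the pair by a margin that lies beyond the usual scatter of this assay.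

Compound 3, `CC1=NC(C)=C(C(=O)OCN2C(=O)c3ccccc3S2(=O)=O)C(c2ccccc2[N+](=O)[O-])/C1=C(\O)OCC1CCCCO1`, is not yet measured. It differs from compound 2 in one place: oxan-2-yl in place of hydrogen on a saturated chain carbon bound to an oxygen on an unsaturated carbon. Put another way, the methoxy of compound 2 becomes a (oxan-2-yl)methoxy in compound 3, while the rest of the shared core is unchanged.

Going by the values given here, no measured pair shows this particular change, so its size can only be guessed. The change adds a ring to the ester side chain and leaves the remainder of compound 2 intact, and the pair of compounds 1 and 2 tells nothing about it. The account expects compound 3 to give a step from compound 2 of a 1.7-fold lower number from compound 2 to compound 3 (0.23 log units; within the scatter), a shift that may well fall within the scatter. The expected value for compound 3 in this assay is therefore 18 nM, with a range from 5 nM to 65 nM.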

Compound 3, half-maximal inhibitory concentration: 25.1 nM
Compound 3: the middle estimate sits 1.4-fold (0.14 log units) below what was measured; low and high end bracket the measured number.
By their numbers in this assay, from the lowest: compound 1; then compounds 3 and 2 (each within the scatter of the next).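

Going by these compounds alone, the step in this assay, a 1.2-fold lower number from compound 2 to compound 3 (0.09 log units; within the scatter), is the first reading of a change in one place, since compound 1 and compound 2 differ in more than one place. It shows that on this saturated chain carbon bound to an oxygen on an unsaturated carbon, oxan-2-yl can stand in place of hydrogen, turning the methoxy into a (oxan-2-yl)methoxy, and compound 3 still reads the same as compound 2 within the scatter, despite the added six-membered non-aromatic ring. No measurement at hand explains why this side chain makes so little difference to the number.

The compounds shown leave open whether the ring oxygen of oxan-2-yl matters, which a cyclohexyl at the same place would test, and whether a longer open chain or a chain ending in a tertiary amine would also stay within the scatter of compound 2. They also leave open whether oxan-2-yl would give a similar step on the core of compound 1, which carries its nitro group at a different place on the phenyl ring and a tert-butyl ester.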